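The source may hold more compounds than are shown below. What is called first, only, known or untested is meant among the compounds shown, and "the series" means these compounds.

Measured in a functional assay on HEL cells (Homo sapiens) for cytotoxicity, read by microscopy (on this read-out higher numbers stand for lower toxicity in this test and lower numbers for higher toxicity in this test), so far. Compound 1 `COC(=O)CC(=O)NC1=CS(=O)(=O)O[C@@]12[C@@H](CO[Si](C)(C)C(C)(C)C)O[C@@H](n1cc(C)c(=O)n(C)c1=O)[C@@H]2O[Si](C)(C)C(C)(C)C` gives 400000 nM. Compound 2 `Cc1cn([C@@H]2O[C@H](CO[Si](C)(C)C(C)(C)C)[C@@]3(OS(=O)(=O)C=C3NCCC(=O)O)[C@H]2O[Si](C)(C)C(C)(C)C)c(=O)n(C)c1=O` gives 80000 nM. Compound 3 `Cc1cn([C@@H]2O[C@@H]3COC(=O)[C@]3(OS(C)(=O)=O)[C@H]2O)c(=O)[nH]c1=O` reaches only a limit of the assay, >= 400000 nM.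

Among the numbers shown, compound 2 stands lowest, with compound 1 nearest and separated from it by more than the scatter. Compound 4 `Cc1cn([C@@H]2O[C@H](CO[Si](C)(C)C(C)(C)C)[C@@]3(OS(=O)(=O)C=C3NC(=O)NC(=O)c3ccccc3)[C@H]2O[Si](C)(C)C(C)(C)C)c(=O)n(C)c1=O` differs from compound 2 by benzoylcarbamoyl in place of 2-carboxyethyl on an amine nitrogen. Within the data shown here, the one measured step at this nitrogen, a 5.0-fold lower number from compound 1 to compound 2 (0.70 log units; beyond the scatter), replaced a carbonyl-bearing group with 2-carboxyethyl and lowered the number. Compound 4 carries benzoylcarbamoyl on that nitrogen, so it resembles compound 1 more than compound 2, and a modest rise is expected, a 3.1-fold higher number from compound 2 to compound 4 (0.49 log units; beyond the scatter). Compound 4 is therefore estimated at 250000 nM, within 80000 nM to 400000 nM in this assay.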

Compound 4, minimum cytotoxic concentration: >= 80000 nM
Compound 4 ended at the assay's limit; the forecaster's own chance of this, stated with the estimate: 35%; the middle value does not contradict the limit.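

In this assay compound 4 gives >= 80000 nM, which is a limit of the assay. Benzoylcarbamoyl, with its six-membered aromatic ring, gives a number no lower from compound 2 to compound 4 (the limit leaves the size open), so this larger group on the amine nitrogen does not take the number below that of 2-carboxyethyl. Neither step to compound 4 can be read in size, because its value is a limit: the limit of >= 80000 nM in this assay, at which 1 of the 4 values shown sits.

The compounds shown leave open how a free amine or a longer chain ending in a carboxylic acid would read on this nitrogen.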